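This account rests on a few compounds, and the source may have more. Where it says the series, first, only, none or still open, it means among the compounds named here.

Working notes on the series in a functional assay on A549 cells (Homo sapiens) for inhibition, read by MTT assay, with a stated time of 72 h; a higher number here means a weaker inhibitor, a lower number a stronger inhibitor. Compound 1 `COC(=O)c1ccc(-n2cc(CCCc3nnc(-c4ccc(C)cc4)[nH]3)nn2)cc1` gives 79500 nM. Compound 2 `COC(=O)c1ccc(-n2nncc2CCCOS(=O)(=O)c2ccc(C)cc2)cc1` reaches only a limit, > 100000 nM. Compound 3 `COC(=O)c1ccc(-c2cn(CCCC(=O)Nc3ccc(C)cc3)nn2)cc1` also reaches only a limit, > 100000 nM. Its standing is therefore known only as a limit, which it shares with one other compound.

Compound 4 `Cc1ccc(NC(=O)CCCn2cc(-c3ccc(C(F)(F)F)cc3)nn2)cc1` follows from compound 3 by one change, trifluoromethyl in place of methoxycarbonyl on an aromatic carbon, para to a large group.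

Among the measured compounds shown here, no step between measured compounds is available to size this change, and the series offers only (the limit of > 100000 nM in this assay, at which 2 of the 3 values shown sit). The estimated at least 1.2-fold lower number from compound 3 to compound 4 (0.09 log units; that floor lies within the scatter) is expected to stay within the usual scatter of this assay, with no firm direction. Compound 4 is estimated at 80000 nM, with an expected range of 35000 nM to 180000 nM.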

Compound 4, half-maximal inhibitory concentration: 25000 nM
For compound 4 the middle estimate is 3.2-fold (0.51 log units) above the measured one; the whole stated range lies above it.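

Trifluoromethyl in place of methoxycarbonyl on an aromatic carbon, para to a large group, gives an at least 4.0-fold lower number from compound 3 to compound 4 (0.60 log units; beyond the scatter) in this assay. Among the compounds shown here, this is the first sized step, and it shows that this position responds to this change. The step is only a floor, and its full size cannot be read: the limit of > 100000 nM in this assay, at which 2 of the 4 values shown sit.

On these data alone, whether a carboxylic acid, a nitrile or a chlorine atom at this position would lower the number further remains open. Also open, as far as these compounds go, is whether the same change would carry over to the core of compound 1 or compound 2, which also bear methoxycarbonyl.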